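Extending the acid chain of compound 2

The source may report more compounds than this note shows. Statements on the series, on what has been measured and on what is new or still open speak of the compounds shown alone.

Measured compounds:
Compound 1 `O=C(O)CCN1Cc2ccc(NC(=O)c3ccc(C4CCNCC4)cc3)cc2C1=O` gives 9600 nM.
Compound 2 `O=C(O)CCN1Cc2ccc(NC(=O)c3ccc4c(c3)CNCC4)cc2C1=O` gives 1100 nM.
Compound 3 `O=C(O)CCCN1Cc2ccc(NC(=O)CCCC3CCNCC3)cc2C1=O` gives 51000 nM.

All three were run in a functional assay on a cell-free system (Platelet, plasma, Homo sapiens) for inhibition; on this read-out higher numbers stand for weaker inhibition and lower numbers for stronger inhibition. Compound 2 has the lowest number of the three; compound 1 sits beyond the scatter above it, and compound 3 further still. Compound 4 `O=C(O)CCCN1Cc2ccc(NC(=O)c3ccc4c(c3)CNCC4)cc2C1=O` is not yet measured. It differs from compound 2 by carboxymethyl in place of carboxy on a saturated chain carbon, two bonds along the chain from an amide-type nitrogen in a ring. For the measured compounds named here, no measured pair isolates this single change: compound 3 carries the longer chain but also a different amide side chain, so its gap to compound 1 cannot be assigned to the chain alone. The expected step from compound 2 to compound 4 in this assay is a 2.3-fold higher number from compound 2 to compound 4 (0.36 log units; beyond the scatter), a modest move toward weaker inhibition. Compound 4 is expected at 2500 nM, within 800 nM to 8000 nM.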

Compound 4, half-maximal inhibitory concentration: 330000 nM
Compound 4: middle estimate off by 130-fold (2.12 log units), on the low side; measured number outside the range, above it.
By their numbers in this assay, from the lowest: compound 2; then compound 1; then compound 3; then compound 4.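

In this assay the acid chain proves a steep position, with a 300-fold higher number from compound 2 to compound 4 (2.48 log units; beyond the scatter) for carboxymethyl in place of carboxy. For the compounds shown here, this is the first pair that isolates the chain, with the amide side chain held the same, so the earlier compounds could not show this sensitivity. Nothing at hand explains the size of the step. Still open, as far as these compounds go, is whether a shorter chain ending in a carboxylic acid or a longer one would keep this trend. Also open, from the compounds shown here alone, is whether the same change on compound 1 would cost as much.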